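Trimming the Amine Tail of Compound 1

The source may report more compounds than this note shows. Statements on the series, on what has been measured and on what is new or still open speak of the compounds shown alone.

Compound 1: `CCN(CC)Cc1ccc2nc(NC(=O)N/N=C/c3cn(Cc4ccccc4Cl)c4ccccc34)sc2c1` gives 980 nM in a functional assay on NCI-H460 cells (Homo sapiens) for cytotoxicity, read by MTT assay, with a stated time of 72 h; on this read-out higher numbers stand for weaker inhibition and lower numbers for stronger inhibition.
Compound 2: `CC1CCN(Cc2ccc3nc(NC(=O)N/N=C/c4cn(Cc5ccc(Cl)cc5Cl)c5ccccc45)sc3c2)CC1` gives 1660 nM in this assay.
Compound 3: `CCN(CC)Cc1ccc2nc(NC(=O)N/N=C/c3c[nH]c4ccccc34)sc2c1` gives 3140 nM in this assay.

Among the three numbers, compound 1 has the lowest. The value of compound 2 lies within the usual scatter of that of compound 1, so the two cannot be told apart. Among the compounds with values here, compound 3 is further away: the single step of a 3.2-fold higher number from compound 1 to compound 3 (0.51 log units; beyond the scatter) is the only measured change in one place, and it concerns the group on the aromatic nitrogen, not the amine.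

Compound 4, `CN(C)Cc1ccc2nc(NC(=O)N/N=C/c3cn(Cc4ccccc4Cl)c4ccccc34)sc2c1`, keeps everything of compound 1 except that it carries dimethylamino in place of diethylamino on a saturated chain carbon bound to an aromatic carbon. Within the data shown here, no measured step addresses this part of the molecule. Among the measured compounds shown here, compound 2 differs from compound 1 both at its amine and at its benzyl group, so its value shows only that those two changes together leave the number within the scatter of compound 1. With nothing measured on the amine alone, the expected step from compound 1 to compound 4 is none beyond the scatter, so a 1.1-fold higher number from compound 1 to compound 4 (0.05 log units; within the scatter) is estimated. Compound 4 is thus expected to give 1100 nM, within a range from 500 nM to 2500 nM.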

Compound 4, half-maximal inhibitory concentration: 1600 nM
For compound 4 the middle estimate is 1.5-fold (0.16 log units) below the measured one, and the stated range covers the measured number.
By their numbers in this assay, from the lowest: compounds 1, 4, 2 and 3 (each within the scatter of the next, the first and the last beyond it).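

In this assay, within the data shown here, the change from diethylamino to dimethylamino on a saturated chain carbon bound to an aromatic carbon gives a 1.6-fold higher number from compound 1 to compound 4 (0.21 log units; within the scatter), the first reading of this position taken alone. Compound 2 could not supply this reading, since it differs from compound 1 at its benzyl group as well as at its amine; here the amine alone is changed, and compound 1 and compound 4 cannot be told apart in this read-out, even though dimethylamino has fewer heavy atoms than diethylamino. Nothing available explains this result or says what lies behind the closeness of the two numbers.

As far as these compounds go, only these two small dialkylamino groups have been compared on their own at this place, so how a morpholine, a primary amine or a carboxylic acid would read there remains open. It also remains open whether dimethylamino would read the same way alongside the hydrogen on the aromatic nitrogen of compound 3, or alongside the dichlorobenzyl group of compound 2, since the compounds shown pair it only with the 2-chlorobenzyl group.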